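The source may report more compounds than this note shows. Statements on the series, on what has been measured and on what is new or still open speak of the compounds shown alone.

Compound 1 `Cc1cccc(Oc2ccnc(N3CCC[C@H]3C(=O)NCc3cccnc3)n2)c1` was tested in an assay on isolated protein for inhibition of RAC-alpha serine/threonine-protein kinase (Homo sapiens), read by HTRF, tested at 10 uM (a higher number here means more inhibition at the concentration tested (going by the name of the read-out), a lower number less inhibition), and in that test compound 1 gives 0%. A second compound built on a different core, compound 2 `Cc1cccc(Nc2ncnc3c2CN(C(=O)c2ccc(N(C)C)c4ccccc24)CC3)c1`, gives 0% in this assay, so compound 1 stands level with compound 2 at the digits shown, the two lying within the usual scatter of each other. Neither shows inhibition at the concentration tested.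

Compound 3 `COC(=O)C(CO)NC(=O)[C@@H]1CCCN1c1nccc(Oc2cccc(C)c2)n1` has not yet been measured. It differs from compound 1 in one place: 2-hydroxy-1-(methoxycarbonyl)ethyl in place of (pyridin-3-yl)methyl on an amide-type nitrogen. The part that leaves carries one ring, the part that enters none.

Among the measured compounds shown here, no measured pair shows what such an exchange does to the read-out, and with both measured compounds at the floor there is no trend to lean on; the step is expected to be a number 2 percentage points higher from compound 1 to compound 3 (within the scatter), which is to say none beyond the scatter. Compound 3 is therefore estimated at 2%, with a range from -10% to 15%.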

Compound 3, a percentage reported as inhibition, at one concentration (the size of the read-out at that concentration, not a potency): 0%
Compound 3: the middle estimate sits 2 percentage points above what was measured; measured number inside the range.
By their numbers in this assay, from the lowest: compounds 1, 2 and 3 (each within the scatter of the next).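

In this assay, putting 2-hydroxy-1-(methoxycarbonyl)ethyl in place of (pyridin-3-yl)methyl on the amide-type nitrogen gives no change at the digits printed from compound 1 to compound 3 (within the scatter), so a group with one aromatic ring and a group with no ring read alike here at the concentration tested. Among the compounds shown here, compound 1 already showed no inhibition, so this step shows only that the exchange does not bring inhibition into view; it cannot show whether the change would have lowered activity in a compound that had some. Nothing measured here offers an explanation for this result.

As far as these compounds go, whether another group on this nitrogen, such as a carboxylic acid or a longer chain ending in an amine, would give any inhibition remains open. So does whether changing another part of the structure shared by compound 1 and compound 3 would do so.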